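The source may hold more compounds than are shown below. What is called first, only, known or untested is meant among the compounds shown, and "the series" means these compounds.

In a physicochemical assay for solubility, in phosphate buffer, with a stated time of 2 h, at pH 7.4 (on this read-out lower numbers stand for lower solubility and higher numbers for higher solubility), compound 3 (`COc1ccc(-c2cc(=O)oc3ccc(F)cc23)cn1`) gives 80000 nM as its reading. Compound 1 (`COc1ccc(-c2cc(=O)oc3ccc(Cl)cc23)cc1O`) gives 40000 nM and compound 2 (`COc1ccc(-c2cc(=O)oc3ccc(C)cc23)cc1O`) gives 40000 nM in the same measurement, so compound 3 stands within the scatter of both and the three numbers do not separate.

The change to compound 4 (`COc1ccc(-c2cc(=O)oc3ccccc23)cn1`), which has not yet been measured, is hydrogen in place of fluoro on an aromatic carbon and nothing else. For the measured compounds named here, no measured pair shows this exact swap. Going by the values given here, the closest evidence is the single measured step (no change at the digits printed from compound 1 to compound 2 (within the scatter)), where methyl takes the place of chloro on an aromatic carbon. That step involves a different pair of groups on a different core, so it bears on the present change only loosely. Even so, it is the one direct look at a small swap of this kind, and it shows no movement beyond the scatter.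

In this assay the expected step (a 1.1-fold lower number from compound 3 to compound 4 (0.06 log units; within the scatter)) is therefore estimated to stay within the scatter, with no direction favoured. For compound 4 the expected value is 70000 nM with an estimated range from 30000 nM to 160000 nM on the same read-out.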

Compound 4, solubility: 80000 nM
Beside the measured number, compound 4's estimate is 1.1-fold (0.06 log units) below it; measured number inside the range.
By their numbers in this assay, from the lowest: compounds 1, 2, 3 and 4 (each within the scatter of the next).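

In this assay, taking the fluoro off the aromatic carbon of the fused system and leaving hydrogen there gives no change at the digits printed from compound 3 to compound 4 (within the scatter) and so does not separate the two compounds. The earlier step had only exchanged one substituent for another, methyl for chloro, on a different core; this one shows that, on the core of compound 3, the reading does not depend on fluoro being present at this position, since the bare carbon reads the same within the scatter. Nothing in the data shown explains why the reading holds when the fluoro goes, so the step stands as an observation without a cause.

Going by these compounds, what remains open is whether this indifference extends beyond small substituents: an amine, a carboxylic acid or a longer chain such as butyl on the same aromatic carbon could leave the reading where it is or move it beyond the scatter. On these data alone, it is also open whether hydrogen in place of fluoro would behave the same way on the core of compound 1, since this single step speaks only for the core of compound 3.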